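The compounds below may be only part of what the source reports. "The series", "measured", "known", "first", "only" and "open" are said of these compounds alone.

Measured compounds: compound 1 `OCCCCc1cn(CCNc2nonc2/C(=N/O)Nc2ccc(F)c(Br)c2)nn1` with 80 nM in an assay on isolated protein for inhibition of Indoleamine 2,3-dioxygenase 1 (Homo sapiens); a lower number here means a stronger inhibitor, a higher number a weaker inhibitor; compound 2 `CC(O)c1cn(CCNc2nonc2/C(=N/O)Nc2ccc(F)c(Br)c2)nn1` with 53 nM; compound 3 `CC(C)(O)c1cn(CCNc2nonc2/C(=N/O)Nc2ccc(F)c(Br)c2)nn1` with 115 nM.

Compound 1 gives the second highest of the three numbers in this assay, and its steps to both neighbours, a 1.5-fold lower number from compound 1 to compound 2 (0.18 log units; within the scatter) and a 1.4-fold higher number from compound 1 to compound 3 (0.16 log units; within the scatter), stay within the scatter. Compound 4 `CC(C)CC(C)(O)c1cn(CCNc2nonc2/C(=N/O)Nc2ccc(F)c(Br)c2)nn1` differs from compound 1 by 1-hydroxy-1,3-dimethylbutyl in place of 4-hydroxybutyl on an aromatic carbon. Among the compounds with values here, two measured steps bear on this: exchanging 4-hydroxybutyl for a tertiary alcohol, a 1.4-fold higher number from compound 1 to compound 3 (0.16 log units; within the scatter), and adding a methyl at the carbinol carbon, a 2.2-fold higher number from compound 2 to compound 3 (0.34 log units; beyond the scatter), a modest rise. Compound 4 carries a tertiary alcohol with a larger branch, so a small shift toward a higher number in this assay is expected, likely within the scatter, a 1.6-fold higher number from compound 1 to compound 4 (0.21 log units; within the scatter). For compound 4 the estimate is 130 nM, with a range from 60 nM to 280 nM.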

Compound 4, half-maximal inhibitory concentration: 51 nM
Compound 4: the middle estimate sits 2.5-fold (0.41 log units) above what was measured; measured number below the stated range.
By their numbers in this assay, from the lowest: compounds 4, 2, 1 and 3 (each within the scatter of the next, the first and the last beyond it).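

In this assay the rise seen on adding methyl to compound 2 does not continue with a larger chain on the tertiary alcohol: a 2.3-fold lower number from compound 3 to compound 4 (0.35 log units; beyond the scatter) is a modest step beyond the scatter. The larger 1-hydroxy-1,3-dimethylbutyl is accepted here, since a 1.6-fold lower number from compound 1 to compound 4 (0.20 log units; within the scatter) and a 1.0-fold lower number from compound 2 to compound 4 (0.02 log units; within the scatter) both stay within the scatter. No data on hand account for these steps.

Still open, from the compounds shown here alone, is whether an amine or a carboxylic acid in place of the hydroxyl keeps the number in this range, and how a longer chain behaves.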